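Hydroxycarbamoyl chain shortening from compound 3 to compound 4

The source may report more compounds than this note shows. Statements on the series, on what has been measured and on what is new or still open speak of the compounds shown alone.

Going by the values given here, in a functional assay on HepG2 cells (Homo sapiens) for inhibition, read by MTT assay, with a stated time of 72 h (on this read-out lower numbers stand for stronger inhibition and higher numbers for weaker inhibition), compound 3 (`Nc1nc2cc(-c3nn(CCCCCC(=O)NO)c4ncnc(N)c34)ccc2o1`) gives 1990 nM and is the only member with a true number so far. Compound 1 (`Nc1nc2cc(-c3nn(CCCC(=O)NO)c4ncnc(N)c34)ccc2o1`) gives > 50000 nM as a limit of the assay, not a number. Compound 2 (`Nc1nc2cc(-c3nn(CCC(=O)NO)c4ncnc(N)c34)ccc2o1`) gives > 150000 nM as a limit too.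

Compound 4 (`Nc1nc2cc(-c3nn(CC(=O)NO)c4ncnc(N)c34)ccc2o1`) is unmeasured and differs from compound 3 in the chain (hydroxycarbamoyl in place of 4-(hydroxycarbamoyl)butyl on a saturated chain carbon bound to an aromatic nitrogen): hydroxycarbamoyl in place of 4-(hydroxycarbamoyl)butyl on a saturated chain carbon bound to an aromatic nitrogen.

The series shows an at least 25-fold lower number from compound 1 to compound 3 (1.40 log units; beyond the scatter) and also an at least 75-fold lower number from compound 2 to compound 3 (1.87 log units; beyond the scatter) on going to the longer chain; both are large and beyond the scatter. The remaining step (a step that the two limits leave unreadable from compound 1 to compound 2) joins two limits and gives no trend among the short chains. Compound 4 carries (hydroxycarbamoyl)methyl, a shorter chain than that of compound 2. With an at least 75-fold lower number from compound 2 to compound 3 (1.87 log units; beyond the scatter) as the closest guide, a large change toward a higher number is expected in this assay for the reverse direction. The expected step is a 75-fold higher number from compound 3 to compound 4 (1.88 log units; beyond the scatter) and is large. For compound 4 the estimated value is 150000 nM with an expected range of 50000 nM to 500000 nM and the read-out may well come back as a limit.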

Compound 4, half-maximal inhibitory concentration: > 150000 nM
Compound 4: no number, only a limit; the forecaster's own chance of this, stated with the estimate: 80%; the middle value sits exactly at the limit.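

In this assay compound 4 gives > 150000 nM, which is a limit of the assay and not a number. The change from 5-(hydroxycarbamoyl)pentyl to (hydroxycarbamoyl)methyl, on a saturated chain carbon bound to an aromatic nitrogen, gives an at least 75-fold higher number from compound 3 to compound 4 (1.87 log units; beyond the scatter). The shortest chain shown also yields no true number, and compound 3 remains the only member with one. The steps joining compounds 1, 2 and 4 link limits and cannot be read, so the short chains carry no order, and two of them end at one shared limit: the limit of > 150000 nM in this assay, at which 2 of the 4 values shown sit.

As far as these compounds go, with a true number for compound 3 alone, the series gives no measured slope with chain length, and it remains open whether a longer chain than 5-(hydroxycarbamoyl)pentyl would lower the number further or raise it again. Every compound shown ends in hydroxycarbamoyl, so it also remains open how a carboxylic acid or an amine at the end of the chain of compound 3 would read on this assay.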